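A few compounds are considered here, and "the series" means these few. Any claim that something is new, unique, unknown or untested is made for them only; others in the source may bear on it.

Of the compounds shown here, three built on related cores have been tested in a functional assay on K562 cells (Homo sapiens) for antiproliferative activity, read by MTT assay, with a stated time of 48 h; on this read-out lower numbers stand for stronger inhibition and higher numbers for weaker inhibition. Compound 1 `N#CC1=C(N)Oc2cc3oc(-c4ccccc4)cc(=O)c3c(O)c2C12C(=O)N(Cc1ccccc1)c1ccc(Cl)cc12` carries a chloro group and gives 36300 nM. Compound 2 `N#CC1=C(N)Oc2cc3oc(-c4ccccc4)cc(=O)c3c(O)c2C12C(=O)N(Cc1ccccc1)c1ccc(Br)cc12` differs from it in one place: bromo in place of chloro on an aromatic carbon. In this assay compound 2 gives 36400 nM, so the exchange produced a 1.0-fold higher number from compound 1 to compound 2 (0.00 log units; within the scatter). Compound 3 `N#CC1=C(N)Oc2cc3oc(-c4ccccc4)cc(=O)c3c(O)c2C12C(=O)Nc1cc(Cl)ccc12` rests on a different core; how its core differs from the core of compound 1 is not broken down here. In this assay compound 3 gives 9250 nM, the lowest of the three numbers, a gap from compound 1 and from compound 2 that lies beyond the scatter.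

Compound 4 `N#CC1=C(N)Oc2cc3oc(-c4ccccc4)cc(=O)c3c(O)c2C12C(=O)Nc1cc(Br)ccc12` has not been measured. It differs from compound 3 in one place: bromo in place of chloro on an aromatic carbon. The spot carrying the new group is described in the same words for both pairs, so this is the same change already seen between compound 1 and compound 2. For the measured compounds named here, with only that one earlier example to go by, the step from compound 3 to compound 4 is expected to be of about the same size, which is to say no meaningful movement, because a 1.0-fold higher number from compound 1 to compound 2 (0.00 log units; within the scatter) showed none. The expected step is a 1.0-fold higher number from compound 3 to compound 4 (0.01 log units; within the scatter). Compound 4 is therefore estimated at 9500 nM in this assay, with a likely range from 4500 nM to 20000 nM.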

Compound 4, half-maximal inhibitory concentration: 8700 nM
For compound 4 the middle estimate is 1.1-fold (0.04 log units) above the measured one; the measured number falls inside the stated range.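

In this assay, the new pair gives a second reading of the same exchange, bromo in place of chloro on an aromatic carbon, with a 1.1-fold lower number from compound 3 to compound 4 (0.03 log units; within the scatter). Set beside the earlier pair, the exchange reads alike on the two cores, and on neither does it shift the number beyond the usual scatter: the same change on two cores in this assay, a 1.0-fold higher number (0.00 log units; within the scatter) from compound 1 to compound 2 and a 1.1-fold lower number (0.03 log units; within the scatter) from compound 3 to compound 4, 1.1-fold (0.03 log units) apart, within the scatter of two such steps. This supports treating chloro and bromo as interchangeable for this read-out on these two cores, but two pairs make no rule for the whole series, and agreement between two steps of almost no size does not show that a change with a large effect would carry from one core to the other in the same way.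

The compounds shown hold only chloro or bromo on this aromatic carbon, so it remains open what an amine, a methoxy group or a carboxylic acid would do there, and whether such a group would give the same step on both cores. Also open, from the compounds shown here alone, is whether the exchange of chloro for bromo would read the same on a third core or in a different cell line.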